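Removing the glutaminyl amide from a weak binder

The source may report more compounds than this note shows. Statements on the series, on what has been measured and on what is new or still open speak of the compounds shown alone.

Measured so far:
compound 1 `CC(C)Cc1nn(C)c(=O)c2c(SCCCO)n(Cc3cnc(NCCCCCNC(=O)[C@@H](N)CCC(N)=O)c4ccccc34)cc12` – 0.16 nM
compound 2 `CC(C)Cc1nn(C)c(=O)c2c(SCCCO)n(Cc3ccnc(NCCCCCNC(=O)[C@@H](N)CCC(N)=O)c3)cc12` – 500 nM
compound 3 `CC(C)Cc1nn(C)c(=O)c2c(SCCCO)n(Cc3ccc(NCCCCCN)nc3)cc12` – 420 nM

In an assay on Raji cells for inhibition of Monocarboxylate transporter 1 (Homo sapiens), read by MTT assay, with a stated time of 96 h (on this read-out higher numbers stand for an effect only at larger amounts of compound and lower numbers for an effect already at smaller amounts), compound 2 gives the highest number of the three, and compound 1 gives a far lower number, a difference beyond the usual scatter. Compound 3 and compound 2 give numbers within the scatter of each other, so nothing separates them. Compound 4 `CC(C)Cc1nn(C)c(=O)c2c(SCCCO)n(Cc3ccnc(NCCCCCN)c3)cc12` is compound 2 with hydrogen in place of (1-amino-3-carbamoylpropyl)carbonyl on an amine nitrogen. For the measured compounds named here, no measured pair shows this exact change, but compound 3 already carries a terminal amine on its chain and gives 420 nM. Compound 4 is therefore expected to stay close to compound 2, with a step of a 1.1-fold lower number from compound 2 to compound 4 (0.05 log units; within the scatter) that does not exceed the scatter. The estimate for compound 4 is 450 nM, between 150 nM and 1400 nM.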

Compound 4, half-maximal effective concentration: 520 nM
Estimate against measurement, compound 4: 1.2-fold (0.06 log units) below; the range from low to high includes it.
By their numbers in this assay, from the lowest: compound 1; then compounds 3, 2 and 4 (each within the scatter of the next).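

Hydrogen in place of (1-amino-3-carbamoylpropyl)carbonyl on the amine nitrogen gives a 1.0-fold higher number from compound 2 to compound 4 (0.02 log units; within the scatter), so compound 2 and compound 4 cannot be told apart. For the compounds shown here, this is the first direct reading of this change. In this setting, the 9 heavy atoms and the defined stereocentre of the departing group make no measurable difference.

From the compounds shown here alone, whether the same change would matter in compound 1 remains open. So does whether an acetyl group or a longer chain on that nitrogen would match hydrogen. No measurement offers an explanation for the match.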